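Ring-closed amine variant of a long-chain carbamate

A few compounds are considered here, and "the series" means these few. Any claim that something is new, unique, unknown or untested is made for them only; others in the source may bear on it.

Measured compounds:
compound 1 `CCCCCCCCCCCCCC[C@H](OCOC)[C@H](CN(CC)CC)NC(=O)OC(C)(C)C`, 15%
compound 2 `CCCCCCCCCCCCCC[C@H](OCOC)[C@H](CN(C(C)C)C(C)C)NC(=O)OC(C)(C)C`, 26.6%
compound 3 `CCCCCCCCCCCCCC[C@H](OCOC)[C@H](CN(CCCC)CCCC)NC(=O)OC(C)(C)C`, 25.1%

All three were tested in a functional assay on NCI-H358 cells (Homo sapiens) for antiproliferative activity, read by sulforhodamine B assay, with a stated time of 48 h, tested at 10 uM; on this read-out lower numbers stand for less inhibition and higher numbers for more inhibition at the one concentration tested (going by the name of the read-out). Compound 3 stands second highest of the three numbers; one step is a number 1.5 percentage points lower from compound 2 to compound 3 (within the scatter), within the scatter, while the other is a number 10.1 percentage points higher from compound 1 to compound 3 (beyond the scatter), beyond it. Compound 4 `CCCCCCCCCCCCCC[C@H](OCOC)[C@H](CN1CCCCC1)NC(=O)OC(C)(C)C` is the next step: piperidin-1-yl in place of dibutylamino on a saturated chain carbon, two bonds along the chain from an amide-type nitrogen. Among the compounds with values here, the steps that bear on this change are a number 11.6 percentage points higher from compound 1 to compound 2 (beyond the scatter) and a number 10.1 percentage points higher from compound 1 to compound 3 (beyond the scatter), both modest, showing that larger open-chain amines gave somewhat more inhibition than diethylamino. A ring amine of middling size is expected to sit between these, so a small downward step a number 5.1 percentage points lower from compound 3 to compound 4 (within the scatter) is expected. Compound 4 is therefore estimated at 20%, with a range from 8% to 32%.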

Compound 4, a percentage reported as inhibition, at one concentration (the size of the read-out at that concentration, not a potency): 15.2%
The estimate for compound 4 lay 4.8 percentage points above the measured number, within the range that was stated.
By their numbers in this assay, from the lowest: compounds 1, 4, 3 and 2 (each within the scatter of the next, the first and the last beyond it).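

In this assay the ring separates from only one of the open-chain amines: the change from diisopropylamino to piperidin-1-yl gives a number 11.4 percentage points lower from compound 2 to compound 4 (beyond the scatter). Against the other two amines piperidin-1-yl cannot be told apart, with a number 9.9 percentage points lower from compound 3 to compound 4 (within the scatter) and a number 0.2 percentage points higher from compound 1 to compound 4 (within the scatter). No measurement offered here accounts for these steps. Still open, going by these compounds, is how other rings on this chain carbon would read, such as pyrrolidin-1-yl or morpholin-4-yl, which carries a ring oxygen. On these data alone, a free primary amine in the same place is equally open.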